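This account rests on a few compounds, and the source may have more. Where it says the series, first, only, none or still open, it means among the compounds named here.

Measured compounds in a functional assay on NCI-H1299 cells (Homo sapiens) for antiproliferative activity, read by MTT assay, with a stated time of 72 h; on this read-out higher numbers stand for weaker inhibition and lower numbers for stronger inhibition:

Compound 1, `O=C(C1=C(O)C(=O)N(CCCn2ccnc2)C1c1ccc(Br)cc1)c1ccccc1`: 20000 nM
Compound 2, `NC1=C(C(=O)c2ccccc2)C(c2ccc(Br)cc2)N(CCCn2ccnc2)C1=O`: 169000 nM
Compound 3, `O=C(C1=C(Nc2ccc(OC(F)(F)F)cc2)C(=O)N(CCCn2ccnc2)C1c1ccc(Br)cc1)c1ccccc1`: 11500 nM

Among these three, compound 2 gives the highest number, that is, the weakest inhibition of cell growth. Its nearest neighbour is compound 1, separated by an 8.5-fold higher number from compound 1 to compound 2 (0.93 log units; beyond the scatter), a swap of amino in place of hydroxy on a double-bonded ring carbon. Compound 3 lies furthest away, with a 15-fold lower number from compound 2 to compound 3 (1.17 log units; beyond the scatter). Between compound 1 and compound 3 the step is a 1.7-fold lower number from compound 1 to compound 3 (0.24 log units; within the scatter).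

Compound 4, `O=C(C1=C(Nc2cccc(Br)c2)C(=O)N(CCCn2ccnc2)C1c1ccc(Br)cc1)c1ccccc1`, has not yet been measured. It differs from compound 2 in one place: 3-bromophenyl in place of hydrogen on an amine nitrogen.

Going by the values given here, the one measured step that bears directly on this change is the one where 4-(trifluoromethoxy)phenyl replaced hydrogen on the same amine nitrogen, giving a 15-fold lower number from compound 2 to compound 3 (1.17 log units; beyond the scatter). Compound 4 carries a different aromatic group on that nitrogen, so the size of its step is not settled by that single comparison, but a large fall in the number, well beyond the scatter, is expected. The step from compound 2 is estimated as a 14-fold lower number from compound 2 to compound 4 (1.15 log units; beyond the scatter). In this assay compound 4 is accordingly estimated at 12000 nM, with a range from 4000 nM to 40000 nM.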

Compound 4, half-maximal inhibitory concentration: 11500 nM
Beside the measured number, compound 4's estimate is 1.0-fold (0.02 log units) above it; low and high end bracket the measured number.
By their numbers in this assay, from the lowest: compounds 3, 4 and 1 (each within the scatter of the next); then compound 2.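

In this assay, 3-bromophenyl in place of hydrogen on the amine nitrogen gives a 15-fold lower number from compound 2 to compound 4 (1.17 log units; beyond the scatter), so the large fall seen with the 4-(trifluoromethoxy)phenyl group appears again with a second aromatic group on this nitrogen. Those two groups differ in both their substituent and where it sits on the ring, yet the comparison shows no change at the digits printed from compound 3 to compound 4 (within the scatter), which means these compounds do not separate the two groups. Set against the hydroxy group, the result is a 1.7-fold lower number from compound 1 to compound 4 (0.24 log units; within the scatter), so compound 1, compound 3 and compound 4 sit together, and of the four, only compound 2, with its plain amino group, stands apart.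

No evidence shown here explains why adding either aromatic group to the amino nitrogen lowers the number. Also open, going by these compounds, is whether the fall needs an aromatic ring at all, as a cyclohexyl ring or an ethyl chain on the same nitrogen would test, and whether an unsubstituted phenyl or a 4-bromophenyl group would land level with compound 3 and compound 4.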